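The source may hold more compounds than are shown below. What is called first, only, known or untested is meant among the compounds shown, and "the series" means these compounds.

In a functional assay on KB cells (Homo sapiens) for inhibition, read by sulforhodamine B assay, with a stated time of 72 h; a lower number here means a stronger inhibitor of growth, a higher number a weaker inhibitor of growth:
Compound 1 `NNC(=O)CCc1ccncc1-c1ccc2ccccc2c1`: > 10000 nM, a limit.
Compound 2 `CCOC(=O)/C=C/c1ccncc1-c1ccc2cc[nH]c2c1`: 7860 nM.
Compound 3 `O=C(CCc1ccncc1-c1ccc2ccccc2c1)N1CCOCC1`: > 10000 nM, a limit.

Compound 1 has no number, only a limit, and stands at the limit of > 10000 nM in this assay, at which 2 of the 3 values shown sit. Compound 4 `COC(=O)/C=C/c1ccncc1-c1ccc2ccccc2c1` differs from it on an aromatic carbon, opposite the ring nitrogen: 2-(methoxycarbonyl)ethenyl in place of 2-(aminocarbamoyl)ethyl on an aromatic carbon. For the measured compounds named here, the one measured step, a step that the two limits leave unreadable from compound 1 to compound 3, gives no size to carry over. The closest guide is compound 2, which also has an unsaturated ester chain, though on a different core, and gives 7860 nM. On that basis, a modest gain in this assay is expected, towards stronger inhibition of growth. The estimated step is an at least 1.6-fold lower number from compound 1 to compound 4 (0.22 log units; that floor lies within the scatter). For compound 4 the estimated value is 6000 nM, with an expected range of 2000 nM to 10000 nM.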

Compound 4, concentration for 50% growth inhibition: 6730 nM
The estimate for compound 4 lay 1.1-fold (0.05 log units) below the measured number; the range from low to high includes it.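

In this assay, for the compounds shown here, the 2-(methoxycarbonyl)ethenyl chain, on the aromatic carbon opposite the ring nitrogen, gives the first readable number on the core of compound 1. The change is an at least 1.4-fold lower number from compound 1 to compound 4 (0.17 log units; that floor lies within the scatter), so any real gain remains unproven, though its true size could be larger. The step has only a floor because compound 1 gives a limit, not a number: the limit of > 10000 nM in this assay, at which 2 of the 4 values shown sit.

Open, on these data alone, is whether the chain's double bond or its methyl ester accounts for the step, which a saturated 2-(methoxycarbonyl)ethyl chain would separate. As far as these compounds go, how a carboxylic acid or an amine would read at this position also remains open.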